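Aryl replacements on the shared core: solubility notes

A few compounds are considered here, and "the series" means these few. Any claim that something is new, unique, unknown or untested is made for them only; others in the source may bear on it.

Compound 3 `Cc1cc(NCc2ccccn2)n2ncc(-c3ccc(F)cc3F)c2n1` returns only a limit in a physicochemical assay for solubility, read by HPLC, using the shake flask method, measured as kinetic solubility, with a stated time of 2 h, at pH 7.4 (on this read-out higher numbers stand for higher solubility and lower numbers for lower solubility), namely < 5000 nM. Compound 1 `Cc1cc(NCc2ccccn2)n2ncc(-c3ccc(N(C)C)cc3)c2n1` likewise stands at a limit of < 5000 nM in this assay. Compound 2 `Cc1cc(NCc2ccccn2)n2ncc(-c3ccc(F)c(Cl)c3)c2n1` also gives a limit, < 5000 nM. The steps a step that the two limits leave unreadable from compound 1 to compound 2, a step that the two limits leave unreadable from compound 1 to compound 3 and a step that the two limits leave unreadable from compound 2 to compound 3 cannot be sized because of the limit of < 5000 nM in this assay, at which 3 of the 3 values shown sit. Compound 4 `Cc1cc(NCc2ccccn2)n2ncc(-c3ccncc3)c2n1` differs from compound 3 by pyridin-4-yl in place of 2,4-difluorophenyl on an aromatic carbon. All three measured steps bear on this change only in that none of them could be read, so neither direction nor size is readable from them, and the expectation rests on the shared limit alone. Compound 4 is therefore expected to show a step of an at least 1.6-fold higher number from compound 3 to compound 4 (0.20 log units; that floor lies within the scatter) in this assay. The estimated solubility of compound 4 is 8000 nM, with a range from 2000 nM to 40000 nM.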

Compound 4, solubility: 161000 nM
For compound 4 the middle estimate is 20-fold (1.30 log units) below the measured one; measured number outside the range, above it.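

In this assay, going by these compounds alone, pyridin-4-yl is the first group at this position to give a readable number rather than a limit, and the steps to it are large (an at least 32-fold higher number from compound 3 to compound 4 (1.50 log units; beyond the scatter)) and (an at least 32-fold higher number from compound 2 to compound 4 (1.50 log units; beyond the scatter)) and (an at least 32-fold higher number from compound 1 to compound 4 (1.50 log units; beyond the scatter)). Each of these starts from a limit, so only a floor is known. The steps among the three aryl compounds cannot be read, and those groups stay unordered because they share one limit: (the limit of < 5000 nM in this assay, at which 3 of the 4 values shown sit).

Open, going by these compounds, is how unsubstituted phenyl or pyridin-3-yl would read at this position. The step therefore cannot yet be tied to the ring nitrogen rather than to the loss of the halogens or the dimethylamino group.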